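Moving a methyl around the outer ring

A few compounds are considered here, and "the series" means these few. Any claim that something is new, unique, unknown or untested is made for them only; others in the source may bear on it.

In an assay for inhibition of 3-hydroxy-3-methylglutaryl-coenzyme A reductase (Rattus norvegicus) (a lower number here means a stronger inhibitor, a higher number a weaker inhibitor), compound 1 `Cc1ccccc1-c1cc(Cl)cc(Cl)c1/C=C/[C@@H]1C[C@@H](O)CC(=O)O1` gives 370 nM, the lower of the two numbers measured; compound 2 `O=C1C[C@H](O)C[C@@H](/C=C/c2c(F)cc(F)cc2-c2ccc(F)cc2)O1` gives 860 nM, a gap beyond the scatter. Compound 3 `Cc1ccc(-c2cc(Cl)cc(Cl)c2/C=C/[C@@H]2C[C@@H](O)CC(=O)O2)cc1` keeps the same atoms as compound 1, joined differently: 4-methylphenyl in place of 2-methylphenyl on an aromatic carbon. Going by the values given here, no measured pair shows such a swap, so the direction is uncertain. With the methyl moved, compound 3 is expected to show the step of a 1.9-fold higher number from compound 1 to compound 3 (0.28 log units; within the scatter). Compound 3 is therefore estimated at 700 nM, within 250 nM to 2000 nM.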

Compound 3, half-maximal inhibitory concentration: 190 nM
Beside the measured number, compound 3's estimate is 3.7-fold (0.57 log units) above it; the whole stated range lies above it.
By their numbers in this assay, from the lowest: compounds 3 and 1 (each within the scatter of the next); then compound 2.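

In this assay, 4-methylphenyl in place of 2-methylphenyl gives a 1.9-fold lower number from compound 1 to compound 3 (0.29 log units; within the scatter), so the two placements of the methyl cannot be told apart. Going by these compounds alone, this is the first pair that differs in one place, and it shows that moving the methyl around this ring leaves the number within the usual scatter. Nothing shown explains this outcome.

Going by these compounds, whether an amine or a longer chain in place of the methyl would give a real difference stays open. Compound 2 differs from compound 1 in more than one place, so the role of the chloro groups also remains unresolved.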